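This account rests on a few compounds, and the source may have more. Where it says the series, first, only, none or still open, it means among the compounds named here.

Measured so far in an assay for inhibition of Amine oxidase [flavin-containing] A (Rattus norvegicus); on this read-out higher numbers stand for weaker inhibition and lower numbers for stronger inhibition:
compound 1 `Cc1ccc(COc2ccc(-c3nn(CCC#N)c(=S)o3)cc2)cc1`; compound 1 gives 10000 nM
compound 2 `N#CCCN1N=C(c2ccc(OCc3ccccc3)cc2)OCC1=O`; compound 2 gives 160000 nM

Compound 2 holds the higher of the two numbers in this assay; compound 1 sits at a much lower number, a gap beyond the scatter. Compound 3 `COc1cccc(COc2ccc(C3=NN(CCC#N)C(=O)CO3)cc2)c1` is not yet measured. It differs from compound 2 in one place: methoxy in place of hydrogen on an aromatic carbon. Within the data shown here, no measured pair shows this change, so its effect is unknown here. For a change this small on the benzyl group, no step beyond the scatter is expected in either direction. Compound 3 is therefore estimated at 120000 nM, with a range from 40000 nM to 400000 nM. The expected step is a 1.3-fold lower number from compound 2 to compound 3 (0.12 log units; within the scatter).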

Compound 3, half-maximal inhibitory concentration: 32000 nM
The estimate for compound 3 lay 3.8-fold (0.57 log units) above the measured number; the whole stated range lies above it.
By their numbers in this assay, from the lowest: compound 1; then compound 3; then compound 2.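

In this assay, among these compounds, replacing benzyl with 3-methoxybenzyl gives a 5.0-fold lower number from compound 2 to compound 3 (0.70 log units; beyond the scatter) and so shows that the number responds to a substituent on this aromatic carbon, which the earlier compounds did not show. Lower numbers here mean stronger inhibition, so this change strengthens inhibition in this pair. Nothing available explains the step.

From the compounds shown here alone, whether a hydroxyl, a fluorine or a longer alkoxy chain on this carbon would move the number the same way remains open. This single pair also leaves open whether the change would carry over to the core of compound 1.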